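This account rests on a few compounds, and the source may have more. Where it says the series, first, only, none or still open, it means among the compounds named here.

In an ADME assay on a cell-free system (plasma, Mus musculus) for metabolic stability, read by LC-MS, tested at 2 uM (on this read-out higher numbers stand for a longer-lived compound and lower numbers for a shorter-lived compound), compound 1 `CN1CCC(c2ccc3c(c2)oc(=O)n3C(=O)NCCCCc2ccc(F)cc2)CC1` gives 0.333 h and compound 2 `CC(C)CNC(=O)n1c(=O)oc2cc(C3CCCN(C)C3)ccc21` gives 0.833 h, the higher of the two numbers, with the gap beyond the usual scatter. Compound 3 `CC(C)CNC(=O)n1c(=O)oc2cc(C3CCN(C)CC3)ccc21` is not yet measured. Its change from compound 2 is 1-methylpiperidin-4-yl in place of 1-methylpiperidin-3-yl on an aromatic carbon. Among the compounds with values here, no measured pair shows this change alone, so this assay offers no direct guide. The expected step, a 1.0-fold lower number from compound 2 to compound 3 (0.02 log units; within the scatter), is none beyond the scatter, in either direction. The estimate for compound 3 is 0.8 h, with an expected range of 0.35 h to 1.8 h.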

Compound 3, half-life: 1.33 h
Estimate against measurement, compound 3: 1.7-fold (0.22 log units) below; low and high end bracket the measured number.
By their numbers in this assay, from the lowest: compound 1; then compounds 2 and 3 (each within the scatter of the next).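

Putting 1-methylpiperidin-4-yl in place of 1-methylpiperidin-3-yl on the aromatic carbon gives, in this assay, a 1.6-fold higher number from compound 2 to compound 3 (0.20 log units; within the scatter), so this change of ring attachment does not separate the two compounds. Within the data shown here, the change at the other end, isopropyl in place of 3-(4-fluorophenyl)propyl, gives a 4.0-fold higher number from compound 1 to compound 3 (0.60 log units; beyond the scatter), the only one-place step so far beyond the scatter, and a modest one. Nothing at hand explains either step. Still open, going by these compounds, is how a piperidin-4-yl without the methyl would read at this place. Also open, on these data alone, is how a benzyl or cyclopropylmethyl group would read in place of the chain.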